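Pyridin-3-yl for 4-chlorophenyl on the amide-type nitrogen

The source may hold more compounds than are shown below. What is called first, only, known or untested is meant among the compounds shown, and "the series" means these compounds.

Measured compounds:
compound 1, `CO[C@@H]1CC=C2NN(c3cc4ccccc4[nH]3)C(=O)C[C@]2(C)O1`: 14400 nM
compound 2, `CO[C@@H]1CC=C2NN(c3ccc(Cl)cc3)C(=O)C[C@]2(C)O1`: 24200 nM
compound 3, `CO[C@@H]1CC=C2NN(c3cc4ccccc4[nH]3)C(=O)C[C@]2(c2ccccc2)O1`: 7900 nM

In a functional assay on DU-145 cells (Homo sapiens) for inhibition, read by sulforhodamine B assay, with a stated time of 48 h (a higher number here means a weaker inhibitor, a lower number a stronger inhibitor), compound 2 gives the highest of the three numbers. Its nearest neighbour is compound 1, whose value lies within the scatter of that of compound 2; compound 3 stands furthest away, beyond the scatter. Going by the values given here, the single step measured in one place, a 1.8-fold lower number from compound 1 to compound 3 (0.26 log units; within the scatter), concerns the saturated ring carbon and not the amide-type nitrogen, so it does not bear directly on the present change. Compound 1 and compound 2 differ in the group on that nitrogen, and their two values sit within the scatter of each other, which is the only hint available.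

Compound 4, `CO[C@@H]1CC=C2NN(c3cccnc3)C(=O)C[C@]2(C)O1`, has not been measured. It differs from compound 2 by pyridin-3-yl in place of 4-chlorophenyl on an amide-type nitrogen in a ring. Among the compounds with values here, with no step on this nitrogen beyond the scatter, no change beyond the scatter is expected: the estimated step is a 1.2-fold higher number from compound 2 to compound 4 (0.09 log units; within the scatter). Compound 4 is therefore expected to give about 30000 nM, within a range from 12000 nM to 80000 nM.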

Compound 4, half-maximal inhibitory concentration: 16400 nM
Compound 4: the middle estimate sits 1.8-fold (0.26 log units) above what was measured, within the range that was stated.
By their numbers in this assay, from the lowest: compounds 3, 1, 4 and 2 (each within the scatter of the next, the first and the last beyond it).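

In this assay, the amide-type nitrogen now has a measured step of its own: a 1.5-fold lower number from compound 2 to compound 4 (0.17 log units; within the scatter). This step replaces 4-chlorophenyl, an aromatic ring of carbon only with no hydrogen-bond acceptor, by pyridin-3-yl, which has a hetero atom in the ring and a hydrogen-bond acceptor, and the two compounds remain within the scatter of each other. Nothing available explains this result or ties it to any property of the two groups.

The compounds shown leave open whether a non-aromatic group on this nitrogen, such as a piperidine ring or a longer alkyl chain, or a pyridin-3-yl ring carrying an amine or a carboxylic acid, would give a step beyond the scatter. They also leave open whether pyridin-3-yl would behave the same way with phenyl in place of methyl on the saturated ring carbon.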